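This account rests on a few compounds, and the source may have more. Where it says the series, first, only, none or still open, it means among the compounds named here.

Measured in a functional assay on SH-SY5Y cells (Homo sapiens) for cytotoxicity, read by MTT assay, with a stated time of 72 h; a lower number here means a stronger inhibitor, a higher number a weaker inhibitor:
- Compound 1 `O=C1c2c[n+]([O-])c3ccccc3c2C(=O)c2c1c1ccccc1n2Cc1cn(CC(O)CO)nn1`: > 1000 nM (a limit of the assay, not a number)
- Compound 2 `O=C1c2c[n+]([O-])c3ccccc3c2C(=O)c2c1c1ccccc1n2CCCCN1CCNCC1`: 1240 nM

For the measured compounds named here, compound 2, at 1240 nM, holds the only true number so far. Compound 1 offers only a limit, > 1000 nM, so the two cannot be placed in order with any precision.

The next compound, compound 3 `CCCN1CCN(CCCCn2c3c(c4ccccc42)C(=O)c2c[n+]([O-])c4ccccc4c2C3=O)CC1`, changes compound 2 in one place: propyl in place of hydrogen on an amine nitrogen in a ring. In words, propyl takes the place of hydrogen on an amine nitrogen in a ring, turning piperazin-1-yl into 4-propylpiperazin-1-yl.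

Going by the values given here, the single measured step, a step that the limit leaves unreadable from compound 1 to compound 2, swaps a whole side group rather than making this change, and it gives no size to carry over. With nothing to set a direction, no step beyond the usual scatter is expected in this assay, and the value of compound 2 remains the anchor, 1240 nM. The expected change is small: a 1.1-fold lower number from compound 2 to compound 3 (0.05 log units; within the scatter).

Compound 3 is estimated at 1100 nM, with an expected range from 400 nM to 3000 nM.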

Compound 3, half-maximal inhibitory concentration: 3970 nM
For compound 3 the middle estimate is 3.6-fold (0.56 log units) below the measured one, outside the stated range (above it).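

In this assay, for the compounds shown here, this is the first step whose size can be read, and it shows that the amine nitrogen in the ring is sensitive to what it carries: propyl in place of hydrogen, which turns piperazin-1-yl into 4-propylpiperazin-1-yl, gives a 3.2-fold higher number from compound 2 to compound 3 (0.51 log units; beyond the scatter). The step is modest but beyond the usual scatter, so on this evidence compound 3 is a weaker inhibitor than compound 2, and this small addition at the far end of the side chain does change the read-out. The value of compound 1 is a limit, and the steps that start from compound 1 cannot be read: the limit of > 1000 nM in this assay, at which 1 of the 3 values shown sits.

Among the compounds shown, this amine nitrogen carries only hydrogen or propyl, so it remains open whether a methyl group, a longer chain such as butyl, or an acetyl group would move the number in the same direction. A single pair also cannot tell why the number rises, or whether the same change would have a similar effect with a shorter or longer chain joining the piperazine ring to the shared core.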